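The source may hold more compounds than are shown below. What is called first, only, known or untested is meant among the compounds shown, and "the series" means these compounds.

Compound 1 `CC(C)c1onc(-c2c(Cl)cccc2Cl)c1COc1ccc(-c2nc3ccc(C(=O)O)cc3n2-c2ccc(F)cc2)cc1`: 2410 nM
Compound 2 `CC(C)c1onc(-c2c(Cl)cccc2Cl)c1COc1ccc(-c2nc3ccc(C(=O)O)cc3n2CC2CC2)cc1`: 2650 nM

Both numbers come from an assay on HEK-293T cells for antagonist activity at vitamin D3 receptor (Homo sapiens), read by a luciferase reporter, with a stated time of 24 h; a lower number here means a stronger inhibitor, a higher number a weaker inhibitor. For the measured compounds named here, compound 2 has the higher of the two numbers, but the only step that reaches it, a 1.1-fold higher number from compound 1 to compound 2 (0.04 log units; within the scatter), lies within the scatter, so the two compounds cannot be told apart on these data.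

Compound 3 `CC(C)c1onc(-c2c(Cl)cccc2Cl)c1COc1ccc(-c2nc3ccc(C(=O)O)cc3n2C2CCCCC2)cc1` differs from compound 2 in a single place: cyclohexyl in place of cyclopropylmethyl on an aromatic nitrogen. Going by the values given here, the one measured step at this same aromatic nitrogen, a 1.1-fold higher number from compound 1 to compound 2 (0.04 log units; within the scatter), exchanged a 4-fluorophenyl for a cyclopropylmethyl and left the number essentially unchanged. With another carbon-only ring entering at that nitrogen, the step expected in this assay is a 1.1-fold lower number from compound 2 to compound 3 (0.03 log units; within the scatter), that is, no change beyond the scatter. Compound 3 is therefore estimated at 2500 nM, with a range from 1000 nM to 6500 nM.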

Compound 3, half-maximal inhibitory concentration: 1450 nM
Beside the measured number, compound 3's estimate is 1.7-fold (0.24 log units) above it; measured number inside the range.
By their numbers in this assay, from the lowest: compounds 3, 1 and 2 (each within the scatter of the next).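

In this assay, the aromatic nitrogen now carries a saturated six-membered carbon ring, and the step of a 1.8-fold lower number from compound 2 to compound 3 (0.26 log units; within the scatter) lies within the scatter, as does the step of a 1.7-fold lower number from compound 1 to compound 3 (0.22 log units; within the scatter). Cyclohexyl, cyclopropylmethyl and 4-fluorophenyl therefore cannot be told apart at this position, so replacing an aromatic ring or a smaller ring with its carbon link by this larger ring gives no clear change in the number. No measurement here offers an explanation for how closely these values agree.

Still open, from the compounds shown here alone, is whether a ring containing an amine, such as piperidinyl, or an open chain, such as n-butyl, would fit this same pattern at the nitrogen. The compounds shown also leave open what an amide in place of the carboxylic acid would do.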